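Swapping the Aryl Group on a Weakly Active Amine

The source may hold more compounds than are shown below. What is called first, only, known or untested is meant among the compounds shown, and "the series" means these compounds.

Compound 1 `CCCc1ccc(NC2=CC(=O)c3nc4n(c3C2=O)[C@H]2OC[C@@H](O)[C@H]2OC4)cc1` carries a 4-propylphenyl group on an amine nitrogen attached to the shared core. In a functional assay on ECa-109 cells for inhibition, with ECa-109 cell line (Homo sapiens) as the target, read by sulforhodamine B assay (on this read-out lower numbers stand for stronger inhibition and higher numbers for weaker inhibition), compound 1 gives > 4000 nM, which is a limit of the assay rather than a number. Two relatives replace that arylamine with a cyclic amine. Compound 2 `O=C1C(N2CCCCC2)=CC(=O)c2c1nc1n2[C@H]2OC[C@@H](O)[C@H]2OC1` gives > 8000 nM, again a limit. Compound 3 `O=C1C(N2CCC2)=CC(=O)c2c1nc1n2[C@H]2OC[C@@H](O)[C@H]2OC1` gives > 16000 nM, also a limit. The step that the two limits leave unreadable from compound 2 to compound 3 therefore cannot be read, as the limits the limit of > 8000 nM in this assay, at which 1 of the 3 values shown sits, and the limit of > 16000 nM in this assay, at which 1 of the 3 values shown sits, show. Compound 4 `CCOc1ccccc1NC1=CC(=O)c2nc3n(c2C1=O)[C@H]1OC[C@@H](O)[C@H]1OC3` differs from compound 1 in one place: 2-ethoxyphenyl in place of 4-propylphenyl on an amine nitrogen. No measured step changes one aryl group for another, so nothing shown here speaks to how this change acts, and the only step measured, between two cyclic amines, is itself unreadable. The step that the limit leaves unreadable from compound 1 to compound 4 is therefore expected to be small, with no reason from the data to expect movement beyond the scatter. Compound 4 is estimated at 8000 nM, within a range from 2500 nM to 40000 nM, and it may well again return only a limit rather than a number.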

Compound 4, half-maximal inhibitory concentration: 4630 nM
Estimate against measurement, compound 4: 1.7-fold (0.24 log units) above; measured number inside the range.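

Compound 4 returns a true number, but compound 1 stands only as a limit, so the change from compound 1 to compound 4 cannot be read as a step of any size. The compounds shown leave open how far exchanging one aryl group for another on the amine nitrogen moves the result in this assay.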